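Hydroxy to methoxy on compound 2: clearance notes

The compounds below may be only part of what the source reports. "The series", "measured", "known", "first", "only" and "open" are said of these compounds alone.

Values so far in an ADME assay on microsomes (Mus musculus) for metabolic stability (on this read-out higher numbers stand for fast clearance and lower numbers for slow clearance), are these.
Compound 1 `CNC(=O)[C@@H]1CCCN1S(=O)(=O)c1ccc(Cl)c(COc2cccc3c(C(F)(F)F)cc(C)nc23)c1Cl` gives 1380 mL/min/kg
Compound 2 `Cc1cc(C(F)(F)F)c2cccc(OCc3c(Cl)ccc(S(=O)(=O)N4CCC[C@H]4CO)c3Cl)c2n1` gives 1630 mL/min/kg
Compound 3 `COC[C@@H]1CCCN1S(=O)(=O)c1ccc(Cl)c(COc2cccc3c(C(F)(F)F)cc(C)nc23)c1Cl` has no value yet

Compound 2, at 1630 mL/min/kg, stands level with compound 1 within the scatter, so the two measured compounds give a single level of clearance. The change to compound 3 is methyl in place of hydrogen on an oxygen on a saturated carbon, in words methyl in place of hydrogen on an oxygen on a saturated carbon, or hydroxymethyl to methoxymethyl. For the measured compounds named here, one measured step bears on it, and only indirectly: a 1.2-fold higher number from compound 1 to compound 2 (0.07 log units; within the scatter), with hydroxymethyl in place of methylcarbamoyl on a saturated ring carbon. Going by the values given here, no measured pair tests the methyl on the oxygen itself, and two compounds are thin ground. Even so, the one step available stays within the scatter, so no step beyond the scatter is expected in this assay, and no direction is favoured. The estimate amounts to a 1.1-fold lower number from compound 2 to compound 3 (0.04 log units; within the scatter) as the expected step. Compound 3 is expected at 1500 mL/min/kg, with an estimated range of 750 mL/min/kg to 3000 mL/min/kg.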

Compound 3, clearance: 1620 mL/min/kg
Beside the measured number, compound 3's estimate is 1.1-fold (0.03 log units) below it; the measured number falls inside the stated range.
By their numbers in this assay, from the lowest: compounds 1, 3 and 2 (each within the scatter of the next).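

In this assay, capping the hydroxy group as methoxy gives a 1.0-fold lower number from compound 2 to compound 3 (0.00 log units; within the scatter), and this pair is the only direct test here of methyl in place of hydrogen on an oxygen on a saturated carbon. Against the methylcarbamoyl compound, the methoxymethyl group gives a 1.2-fold higher number from compound 1 to compound 3 (0.07 log units; within the scatter), so hydroxymethyl, methoxymethyl and methylcarbamoyl on this saturated ring carbon all sit at a single level of clearance, and the hydroxy hydrogen makes no difference that can be read in these three compounds. Nothing measured here accounts for this flat result or shows which part of these compounds sets the clearance.

Going by these compounds, whether the same level holds for a group of another kind on this ring carbon, such as an amine, a carboxylic acid or a longer ether chain, remains open. On these data alone, all three compounds share the same core, so the effect of a change elsewhere in the structure, such as replacing the trifluoromethyl group with a nitrile, also remains open.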